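Removing the para fluorine from compound 3's sulfonyl ring

This account rests on a few compounds, and the source may have more. Where it says the series, first, only, none or still open, it means among the compounds named here.

Measured compounds:
Compound 1 `O=S(=O)(Nc1cc(-c2cnc3[nH]cc(-c4ccncc4)c3c2)cnc1Cl)c1ccccc1F` gives 1790 nM in a functional assay on T47D cells (Homo sapiens) for inhibition, read by sulforhodamine B assay, with a stated time of 72 h; a lower number here means a stronger inhibitor of growth, a higher number a weaker inhibitor of growth.
Compound 2 `O=S(=O)(Nc1cc(-c2cnc3[nH]cc(-c4ccccc4)c3c2)cnc1Cl)c1ccccc1` gives 7720 nM in this assay.
Compound 3 `O=S(=O)(Nc1cc(-c2cnc3[nH]cc(-c4ccncc4)c3c2)cnc1Cl)c1ccc(F)cc1` gives 1300 nM in this assay.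

These three compounds share one core and differ only at the ring on the sulfonyl sulfur and at the ring on the core. On the numbers shown, compound 3 and compound 1 sit close together: the step of a 1.4-fold lower number from compound 1 to compound 3 (0.14 log units; within the scatter) is within the scatter, so no order between them can be claimed. Compound 2, which carries phenyl in place of pyridyl on the core and also a plain phenylsulfonyl, stands clearly apart from both.

Compound 4 `O=S(=O)(Nc1cc(-c2cnc3[nH]cc(-c4ccncc4)c3c2)cnc1Cl)c1ccccc1` is compound 3 with one change: hydrogen in place of fluoro on an aromatic carbon. Within the data shown here, no measured step removes a fluorine outright; the only step on the sulfonyl ring, a 1.4-fold lower number from compound 1 to compound 3 (0.14 log units; within the scatter), merely moves the fluorine and stays within the scatter. Compound 2 cannot serve as a guide, since it differs from compound 4 in a second place as well. The expectation is therefore a step of no real size in this assay, estimated as a 1.2-fold higher number from compound 3 to compound 4 (0.09 log units; within the scatter). Compound 4 is thus expected to give about 1600 nM, within a range of 700 nM to 3600 nM.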

Compound 4, concentration for 50% growth inhibition: 1500 nM
Beside the measured number, compound 4's estimate is 1.1-fold (0.03 log units) above it, and the stated range covers the measured number.
By their numbers in this assay, from the lowest: compounds 3, 4 and 1 (each within the scatter of the next); then compound 2.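

In this assay, hydrogen in place of fluoro gives a 1.2-fold higher number from compound 3 to compound 4 (0.06 log units; within the scatter) for the 4-fluorophenyl pair and a 1.2-fold lower number from compound 1 to compound 4 (0.08 log units; within the scatter) for the 2-fluorophenyl pair, so the sulfonyl ring with no fluorine cannot be told apart from either fluorinated ring. Among these compounds, compound 4 also isolates a single change on the ring on the core, which the earlier compounds could not do because compound 2 differed from each of them in two places: pyridin-4-yl in place of phenyl gives a 5.1-fold lower number from compound 2 to compound 4 (0.71 log units; beyond the scatter), a step that can be read as real of one pair. Nothing given here explains either result.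

The compounds shown leave open whether the sulfonyl ring responds to any group other than fluoro or hydrogen, such as a methoxy group, an amine or a carboxylic acid. They also leave open whether the step at the ring on the core is specific to pyridin-4-yl, or would also appear with another replacement for phenyl, such as pyridin-3-yl or a morpholine ring.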